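The source may report more compounds than this note shows. Statements on the series, on what has been measured and on what is new or still open speak of the compounds shown alone.

Measured so far in an ADME assay on microsomes from liver (Mus musculus) for metabolic stability, read by LC-MS, with a stated time of 30 min, tested at 0.1 uM (on this read-out lower numbers stand for a less stable compound and higher numbers for a more stable compound), for three compounds:
compound 1 `FC(F)(F)c1cccc(-c2nc3cnc(Nc4ccccn4)cc3[nH]2)c1` (47%)
compound 2 `FC(F)(F)Oc1ccc(-c2nc3cnc(Nc4ccccn4)cc3[nH]2)cc1` (62%)
compound 3 `COc1cccnc1Nc1cc2[nH]c(-c3cccc(C(F)(F)F)c3)nc2cn1` (80%)

Compound 3 stands highest of the three. Its value (80%) lies above those of compound 2 (62%) and compound 1 (47%), and both gaps are beyond the scatter.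

Among the compounds with values here, compound 4 `COc1ccc(Nc2cc3[nH]c(-c4cccc(C(F)(F)F)c4)nc3cn2)nc1` has no measurement yet. Against compound 3 the change is 5-methoxypyridin-2-yl in place of 3-methoxypyridin-2-yl on a nitrogen on an aromatic ring with 5-methoxypyridin-2-yl in place of 3-methoxypyridin-2-yl on a nitrogen on an aromatic ring. The two have the same atoms, joined differently.

Within the data shown here, one measured step bears on this group: a number 33 percentage points higher from compound 1 to compound 3 (beyond the scatter) with methoxy in place of hydrogen on an aromatic carbon. That step is large and beyond the scatter. Among the measured compounds shown here, no measured pair shows a methoxy changing place, so the size of this change is not known directly. Compound 4 keeps the methoxy, but the gain of compound 3 over compound 1 may carry over only in part. A fall beyond the scatter in this assay is therefore expected, smaller than the measured step. The estimated step runs a number 18 percentage points lower from compound 3 to compound 4 (beyond the scatter) on this reasoning. For compound 4 the estimated value is 62% (expected range 42% to 78%).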

Compound 4, percent of the compound remaining: 33%
For compound 4 the middle estimate is 29 percentage points above the measured one; measured number outside the range, below it.
By their numbers in this assay, from the lowest: compound 4; then compound 1; then compound 2; then compound 3.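

In this assay the place of the methoxy on the pyridin-2-yl ring sets the direction of its effect as well as its size: with the same atoms joined differently, the change from 3-methoxypyridin-2-yl to 5-methoxypyridin-2-yl gives a number 47 percentage points lower from compound 3 to compound 4 (beyond the scatter) on the aromatic amine nitrogen. Methoxy in place of hydrogen is therefore no general gain at this position, since one placement gives a number 33 percentage points higher from compound 1 to compound 3 (beyond the scatter) and the other gives a number 14 percentage points lower from compound 1 to compound 4 (beyond the scatter) in this pair of comparisons. Nothing on hand explains the difference between the two placements.

Open, from the compounds shown here alone, is whether the gain in compound 3 belongs to the methoxy itself or would also appear with an ethoxy group or a chlorine atom in its place on the pyridin-2-yl ring. Also open, going by these compounds, is whether the same ranking of 3-methoxypyridin-2-yl and 5-methoxypyridin-2-yl holds on the core of compound 2, which carries a trifluoromethoxy group on its phenyl ring instead of the trifluoromethyl group of compounds 1, 3 and 4.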